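The source may hold more compounds than are shown below. What is called first, only, known or untested is meant among the compounds shown, and "the series" means these compounds.

Compound 1 `Cc1ncnc2c1c(I)cn2[C@@H]1O[C@H](CO)[C@@H](O)[C@H]1O` and compound 2 `C#Cc1cn([C@@H]2O[C@H](CO)[C@@H](O)[C@H]2O)c2ncnc(C)c12` share a core and differ in a single place. In a functional assay on HeLa S3 cells (Homo sapiens) for antiproliferative activity, read by XTT assay, with a stated time of 72 h (on this read-out higher numbers stand for weaker inhibition and lower numbers for stronger inhibition), compound 2 gives 14700 nM. Compound 1 gives 4080 nM in this assay. The change between them is iodo in place of ethynyl on an aromatic carbon and it produced a 3.6-fold lower number from compound 2 to compound 1 (0.56 log units; beyond the scatter). Compound 3 `C#Cc1cn([C@@H]2O[C@H](CO)[C@@H](O)[C@H]2O)c2nc(C)nc(N)c12` carries the same ethynyl group as compound 2, but its core differs from the core of compound 2 in a way that is not broken down here. For compound 3 this assay reports only a limit, > 20000 nM. Compound 4 `Cc1nc(N)c2c(I)cn([C@@H]3O[C@H](CO)[C@@H](O)[C@H]3O)c2n1` is obtained from compound 3 by the same change, (iodo in place of ethynyl on an aromatic carbon), in the same surroundings as before. For the measured compounds named here, the only guide to this change is the single step from compound 2 to compound 1, and the starting point for compound 4 is a limit rather than a number, so compound 4 is difficult to place. Compound 4 is expected to give about 12000 nM in this assay, between 4000 nM and 40000 nM, which would mean an expected step of an at least 1.6-fold lower number from compound 3 to compound 4 (0.22 log units; that floor lies within the scatter), though a limit would not be surprising given (the limit of > 20000 nM in this assay, at which 1 of the 3 values shown sits).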

Compound 4, half-maximal inhibitory concentration: 4180 nM
Compound 4: the middle estimate sits 2.9-fold (0.46 log units) above what was measured; the measured number falls inside the stated range.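

In this assay, iodo in place of ethynyl again gives a lower number on the second core, an at least 4.7-fold lower number from compound 3 to compound 4 (0.67 log units; beyond the scatter). Compound 3 has only a limit, > 20000 nM, so this step has a floor but no known upper end. The change therefore lowered the number on both of these cores, which shows that its direction carried over in this pair of cores but not that its size did, and it sets no rule for other cores: the same change on two cores in this assay, a 3.6-fold lower number (0.56 log units; beyond the scatter) from compound 2 to compound 1 and an at least 4.7-fold lower number (0.67 log units; beyond the scatter) from compound 3 to compound 4; the limit leaves it open whether they differ.

The compounds shown leave open how the same change would behave on any further core, since only two pairs can be compared here. They also leave open what bromo, chloro, a nitrile or a longer chain ending in a triple bond would give on this aromatic carbon, and so whether iodo is unusual in lowering the number or is simply one of several groups that would do the same.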